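The compounds below may be only part of what the source reports. "The series", "measured", "known", "first", "only" and "open" are said of these compounds alone.

Compound 1 `Cc1nc(Nc2ccc(Cl)cc2)sc1C(=O)/C=C/c1ccccc1` gives > 25000 nM in a functional assay on NCI-H460 cells (Homo sapiens) for cytotoxicity, read by MTT assay (on this read-out higher numbers stand for weaker inhibition and lower numbers for stronger inhibition), which is a limit of the assay. Compound 2 `Cc1nc(Nc2cccc(Cl)c2)sc1C(=O)/C=C/c1ccccc1` gives > 25000 nM in this assay, also a limit. Compound 3 `Cc1ccccc1Nc1nc(C)c(C(=O)/C=C/c2ccccc2)s1` gives > 25000 nM in this assay, again a limit and not a number.

So compound 3 stands only at a limit, with no measured number to place it. Compound 4 `Cc1cccc(Nc2nc(C)c(C(=O)/C=C/c3ccccc3)s2)c1` differs from it by 3-methylphenyl in place of 2-methylphenyl on a nitrogen on an aromatic ring. The earlier changes at this same nitrogen read a step that the two limits leave unreadable from compound 1 to compound 2, a step that the two limits leave unreadable from compound 1 to compound 3 and a step that the two limits leave unreadable from compound 2 to compound 3, and their size cannot be told because of the limit of > 25000 nM in this assay, at which 3 of the 3 values shown sit. No readable step is therefore available, and compound 4 is expected to stay at the limit as well, a step that the limit leaves unreadable from compound 3 to compound 4. The estimate for compound 4 is 40000 nM, ranging from 15000 nM to 150000 nM.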

Compound 4, half-maximal inhibitory concentration: 21800 nM
The estimate for compound 4 lay 1.8-fold (0.26 log units) above the measured number; the range from low to high includes it.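

Among the compounds shown here, compound 4 is the only one of the four compounds with a number rather than a limit, which gives the first partly readable steps at this nitrogen. 3-Methylphenyl in place of 2-methylphenyl gives an at least 1.1-fold lower number from compound 3 to compound 4 (0.05 log units; that floor lies within the scatter), methyl in place of chloro gives an at least 1.1-fold lower number from compound 2 to compound 4 (0.05 log units; that floor lies within the scatter), and 3-methylphenyl in place of 4-chlorophenyl gives an at least 1.1-fold lower number from compound 1 to compound 4 (0.05 log units; that floor lies within the scatter). Each is only a floor within the scatter, so no true size can be read, and the other compounds stay unplaced: the limit of > 25000 nM in this assay, at which 3 of the 4 values shown sit.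

As far as these compounds go, whether a methoxy group or an amine on this phenyl ring would give a clearly lower number in this assay stays open.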